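Swapping a ring group for a small amide

The source may hold more compounds than are shown below. What is called first, only, known or untested is meant among the compounds shown, and "the series" means these compounds.

Compound 1 `COc1ccc(-c2nc(/N=C(\N)[N+]3(C)CCCCC3)sc2-c2ccc(OC)cc2)cc1`: > 1000 nM in a functional assay with Oryctolagus cuniculus as the target; a higher number here means a weaker inhibitor, a lower number a stronger inhibitor
Compound 2 `COc1ccc(-c2nc(/N=C(\N)n3ccnc3)sc2-c2ccc(OC)cc2)cc1`: > 100 nM
Compound 3 `COc1ccc(-c2nc(CNC(=O)NC(C)C)sc2-c2ccc(OC)cc2)cc1`: 42 nM

Compound 1 gives a limit of this assay, not a number, and it sits at the limit of > 1000 nM in this assay, at which 1 of the 3 values shown sits. For compound 2 the value is also a limit, sitting at the limit of > 100 nM in this assay, at which 1 of the 3 values shown sits. Compound 3 is the only one of the three with a measured number. Compound 1 therefore stands only at a limit, with one further limit among the values shown.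

Compound 4 `CCN(CC)C(=O)c1nc(-c2ccc(OC)cc2)c(-c2ccc(OC)cc2)s1` differs from compound 1 in one place: a group of 7 heavy atoms (5 carbon, 1 nitrogen, 1 oxygen; no ring) in place of a group of 10 heavy atoms (7 carbon, 3 nitrogen; one six-membered non-aromatic ring with 1 hetero atom), on an aromatic carbon. The change that bears most directly on it is an at least 23-fold lower number from compound 1 to compound 3 (1.37 log units; beyond the scatter), where a group without a ring and without net charge likewise replaced the same ring group on the same aromatic carbon. The step that the two limits leave unreadable from compound 1 to compound 2 cannot be read, since both ends are limits, and the step of an at least 2.3-fold lower number from compound 2 to compound 3 (0.37 log units; beyond the scatter) again favours the acyclic group.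

A large drop in the number is therefore expected, in the direction of a stronger inhibitor, with the step from compound 1 to compound 4 estimated as an at least 10-fold lower number from compound 1 to compound 4 (1.00 log units; beyond the scatter). Compound 4 is expected to give about 100 nM in this assay, most likely between 30 nM and 500 nM.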

Compound 4, half-maximal inhibitory concentration: < 10 nM
Compound 4 ended at the assay's limit; the forecaster's own chance of this, stated with the estimate: 15%; middle value at least 10-fold (1.00 log units) away from the limit.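

Compound 4 gives a limit rather than a number in this assay: the limit of < 10 nM in this assay, at which 1 of the 4 values shown sits.

Even so, the limit is enough to show that diethylcarbamoyl on this aromatic carbon gives an at least 100-fold lower number from compound 1 to compound 4 (2.00 log units; beyond the scatter), and also an at least 10-fold lower number from compound 2 to compound 4 (1.00 log units; beyond the scatter), so neither the ring of the group in compound 1, nor its net charge, nor its hydrogen-bond donor is needed for a low number here. What the earlier compounds could not show is that a group without a ring can do better than the one in compound 3, the only measured number so far, with an at least 4.2-fold lower number from compound 3 to compound 4 (0.62 log units; beyond the scatter), which places the carbonyl of an amide directly on the aromatic carbon as the best arrangement among these four compounds.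

On these data alone, because compound 4 stands at a limit, each of these steps is a minimum, and how much lower its true number lies stays unknown. The compounds shown also do not separate the part played by the carbonyl from that of the two ethyl groups, so it remains open how a dimethylcarbamoyl group, a dipropylcarbamoyl group or a carboxylic acid would compare at this position.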